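The source may hold more compounds than are shown below. What is called first, only, known or untested is meant among the compounds shown, and "the series" means these compounds.

Compound 2 `O=C1Cc2cc(NC(=O)[C@H]3CCCN3C(=O)C3(c4cccc(Cl)c4)CCCC3)ccc2N1` is the one of the two measured compounds with the higher number in an assay on isolated protein for inhibition of histone acetyltransferase p300 (Homo sapiens), with a stated time of 60 min; on this read-out higher numbers stand for weaker inhibition and lower numbers for stronger inhibition: compound 2 gives 0.794 nM, while compound 1 `O=C(Nc1ccc2[nH]ncc2n1)[C@H]1CCCN1C(=O)C1(c2ccc(F)cc2)CCC1` gives 0.126 nM. Compound 1 and compound 2 differ in more than one place, so their two values only show that the pair spans a gap beyond the usual scatter, without pointing to either change as its source.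

Compound 3 `O=C(Nc1ccc2[nH]nnc2c1)[C@H]1CCCN1C(=O)C1(c2cccc(Cl)c2)CCCC1` keeps the chlorophenyl-bearing ring and the shared core of compound 2 and changes only the group on the amide nitrogen: a group of 9 heavy atoms (6 carbon, 3 nitrogen; one five-membered aromatic ring with 3 hetero atoms, one six-membered aromatic ring of carbon only) in place of a group of 10 heavy atoms (8 carbon, 1 nitrogen, 1 oxygen; one five-membered non-aromatic ring with 1 hetero atom, one six-membered aromatic ring of carbon only), on an amide-type nitrogen. For the measured compounds named here, no measured pair differs in just this way, so the size of this step has no direct precedent. Going by the values given here, the only hint is that compound 1, whose amide nitrogen also carries a fully aromatic bicyclic group, sits at the lower number, but it differs elsewhere too. A small step toward a lower number, within or only just beyond the scatter, is therefore expected, as a 1.6-fold lower number from compound 2 to compound 3 (0.20 log units; within the scatter). Compound 3 is estimated at 0.5 nM, with a likely range from 0.15 nM to 1.6 nM.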

Compound 3, half-maximal inhibitory concentration: 20 nM
Beside the measured number, compound 3's estimate is 40-fold (1.60 log units) below it; measured number outside the range, above it.
By their numbers in this assay, from the lowest: compound 1; then compound 2; then compound 3.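

In this assay the group on the amide-type nitrogen proves to be a demanding place: swapping one two-ring group for another of nearly the same size gives a 25-fold higher number from compound 2 to compound 3 (1.40 log units; beyond the scatter), a large step beyond the scatter. Size and outline alone therefore do not decide the result here, as both groups combine a five-membered ring with a six-membered aromatic ring of carbon only, and each has 1 hydrogen-bond donor, yet the numbers lie far apart. The groups do differ in other counted features, as the entering group has 3 nitrogen atoms and 2 hydrogen-bond acceptors and lacks the oxygen and the double bond outside aromatic rings, but no measurement available here explains the step.

Which of these differences carries the step stays open, as this is the only measured pair that differs in just this place. Also open, as far as these compounds go, are how a plain phenyl group, or a phenyl group carrying an amine or a carboxylic acid, would behave on the same nitrogen, and whether a step of this size would recur with the other parts of compound 1 in place.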